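The source may hold more compounds than are shown below. What is called first, only, known or untested is meant among the compounds shown, and "the series" means these compounds.

Measured so far:
compound 1 `CN(C)C(=O)N(C)CC#CCn1ccnc1` gives 25.4 mg/kg
compound 3 `O=C1NCCN1CC#CCn1ccnc1` gives 17.3 mg/kg
compound 2 `Cc1cncn1CC#CCN(C)C(=O)N(C)C` gives only a limit, > 100 mg/kg

In a functional assay on the whole organism for agonist activity, with Mus musculus as the target (a higher number here means that more compound is needed for the effect, a lower number that less compound is needed), compound 1 and compound 3 lie within the usual scatter of each other. How the core of compound 1 and the core of compound 3 differ is not broken down here. Compound 2 differs from compound 1 by methyl in place of hydrogen on an aromatic carbon, and that change made an at least 3.9-fold higher number from compound 1 to compound 2 (0.59 log units; beyond the scatter), a step bounded by the limit of > 100 mg/kg in this assay, at which 1 of the 3 values shown sits. Compound 4 `Cc1cncn1CC#CCN1CCNC1=O` has not yet been measured; it differs from compound 3 by the same change, (methyl in place of hydrogen on an aromatic carbon). Given that the change from compound 1 gave an at least 3.9-fold higher number from compound 1 to compound 2 (0.59 log units; beyond the scatter), compound 4 is expected to move by a similar amount, a 5.2-fold higher number from compound 3 to compound 4 (0.72 log units; beyond the scatter). Compound 4 is thus estimated at 90 mg/kg, somewhere between 40 mg/kg and 250 mg/kg, with a real chance that this assay again reports only a limit.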

Compound 4, dose for half-maximal effect: > 100 mg/kg
Compound 4: a limit, no number (the forecaster's own chance of this, stated with the estimate: 55%); middle value at least 1.1-fold (0.04 log units) from the limit.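

In this assay, methyl in place of hydrogen on an aromatic carbon gave an at least 5.7-fold higher number from compound 3 to compound 4 (0.76 log units; beyond the scatter), so the core of compound 3 responds to this change in the same direction as the core of compound 1. Compound 4 gives a limit, not a number: the limit of > 100 mg/kg in this assay, at which 2 of the 4 values shown sit. Whether the change has the same size on both cores cannot be read from these results: the same change on two cores in this assay, an at least 3.9-fold higher number (0.59 log units; beyond the scatter) from compound 1 to compound 2 and an at least 5.7-fold higher number (0.76 log units; beyond the scatter) from compound 3 to compound 4; the limit leaves it open whether they differ.

The compounds shown leave open how ethyl or a chlorine atom would behave at this same place on the ring. They also leave open whether a longer chain joining the ring to the urea part would alter the outcome on either core.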